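Lengthening a Sulfanyl Chain at the Edge of Tolerance

A few compounds are considered here, and "the series" means these few. Any claim that something is new, unique, unknown or untested is made for them only; others in the source may bear on it.

Compound 1, `CSc1cc(NC2CCCC2)cc2c(-c3ccnc(NC4CCCC4)n3)c(-c3ccc(F)cc3)nn12`: in an ADME assay on Vero cells (Chlorocebus sabaeus) for cytotoxicity (a higher number here means that more compound is tolerated, a lower number that less compound is tolerated), compound 1 gives > 40000 nM, which is a limit of the assay rather than a number.
Compound 2, `COc1ccc(-c2nn3c(SC)cc(NC4CCCC4)cc3c2-c2ccnc(NC3CCCC3)n2)cc1`: in this assay compound 2 gives > 40000 nM, again a limit of the assay rather than a number.

On these data alone, compound 2 therefore stands at the ceiling of what this assay reports; where it truly lies above that ceiling is unknown. Compound 1 differs from compound 2 by methoxy in place of fluoro on an aromatic carbon, and the step that the two limits leave unreadable from compound 1 to compound 2 cannot be read because both of its ends sit at the limit of > 40000 nM in this assay, at which 2 of the 2 values shown sit.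

Compound 3, `CCSc1cc(NC2CCCC2)cc2c(-c3ccnc(NC4CCCC4)n3)c(-c3ccc(OC)cc3)nn12`, differs from compound 2 by methyl in place of hydrogen on a saturated chain carbon bound to a sulfur. Within the data shown here, the one measured step bears on this change only by showing that both neighbours were tolerated up to the ceiling; it offers no size and no direction. With nothing pointing to a shift beyond the scatter, compound 3 is expected to behave like compound 2 and to sit at the ceiling again. Compound 3 is estimated at 45000 nM in this assay, with a range from 20000 nM to 100000 nM. The step that the limit leaves unreadable from compound 2 to compound 3 that this estimate implies is expected to stay within the scatter.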

Compound 3, half-maximal cytotoxic concentration: > 40000 nM
Compound 3: a limit, no number; the forecaster's own chance of this, stated with the estimate: 75%; the middle value is on the limit's open side.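

No new step can be read between compound 2 and compound 3, since both give a limit of this assay rather than a number: the limit of > 40000 nM in this assay, at which 3 of the 3 values shown sit.

The compounds shown leave open how much of each is truly tolerated, and whether methoxy versus fluoro or methylsulfanyl versus ethylsulfanyl changes that at all.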